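The source may hold more compounds than are shown below. What is called first, only, known or untested is meant among the compounds shown, and "the series" means these compounds.

Measured compounds:
Compound 1, `O=C(Nc1ccc([N+](=O)[O-])cc1Cl)c1cc(F)ccc1O`, gives 3.3 ug/mL in a physicochemical assay for solubility; on this read-out higher numbers stand for higher solubility and lower numbers for lower solubility.
Compound 2, `O=C(Nc1ccc([N+](=O)[O-])cc1Cl)c1cc([N+](=O)[O-])ccc1O`, gives > 50 ug/mL in this assay; this is a limit of the assay and not a number.
Compound 3, `O=C(Nc1ccc([N+](=O)[O-])c(Cl)c1)c1cc(Cl)ccc1O`, gives < 1 ug/mL in this assay; this too is a limit of the assay and not a number.

The measured step is an at least 15-fold lower number from compound 2 to compound 1 (1.18 log units; beyond the scatter). The change is fluoro in place of nitro on an aromatic carbon. Compound 2 sits at the limit of > 50 ug/mL in this assay, at which 1 of the 3 values shown sits, so the true size of that step may be larger than the lower bound given.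

Compound 4, `O=C(Nc1ccc(F)c(Cl)c1)c1cc(Cl)ccc1O`, is not yet measured. It differs from compound 3 by fluoro in place of nitro on an aromatic carbon. The difference between the cores of compound 3 and compound 2 is not broken down here. The two changes are the same kind of change, not the same: in compound 2 the replaced nitro sits meta to a large group and para to a hydroxy group, whereas in compound 3 it sits ortho to a chloro group and para to a large group.

Compound 3 sits at the limit of < 1 ug/mL in this assay, at which 1 of the 3 values shown sits, so there is no number from which a step can be counted. Going by the values given here, the only measured step of this kind points downward, and compound 3 already gives a limit, so compound 4 is expected to remain at or below that limit; the expected step is a step that the limit leaves unreadable from compound 3 to compound 4. The estimate for compound 4 is 0.6 ug/mL, with a range from 0.15 ug/mL to 2.5 ug/mL.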

Compound 4, solubility: 2.4 ug/mL
Compound 4: the middle estimate sits 4.0-fold (0.60 log units) below what was measured; low and high end bracket the measured number.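

The same kind of change, fluoro in place of nitro on an aromatic carbon, runs in opposite directions across the two cores in this assay: one step is an at least 15-fold lower number from compound 2 to compound 1 (1.18 log units; beyond the scatter) and the other is an at least 2.4-fold higher number from compound 3 to compound 4 (0.38 log units; beyond the scatter). So the direction of this change did not carry from one core to the other in these two pairs, although the new step gives only a lower bound on its size, as compound 3 stands at a limit of the assay and not at a number: the limit of < 1 ug/mL in this assay, at which 1 of the 4 values shown sits. The other step is also only a lower bound, as compound 2 stands at a limit of the assay, so the two sizes cannot be set against each other: the limit of > 50 ug/mL in this assay, at which 1 of the 4 values shown sits.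

The two pairs leave open whether the reversal follows the core as a whole or the place of the replaced nitro, as the two cores differ and the nitro stands in a different place in each. Also open, from the compounds shown here alone, is how an amine or a carboxylic acid on that aromatic carbon would read in this assay on either core.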